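Notes on a benzyl variant of the shared core

The source may hold more compounds than are shown below. What is called first, only, known or untested is meant among the compounds shown, and "the series" means these compounds.

Measured compounds:
Compound 1, `COc1ccc(Oc2ccc3cc(NC(=O)c4ccc(OC)c(-c5cccc(OC)c5)c4)c(=O)oc3c2C)cc1`: in a functional assay on SK-BR-3 cells (Homo sapiens) for antiproliferative activity (on this read-out higher numbers stand for weaker inhibition and lower numbers for stronger inhibition), compound 1 gives only a limit, > 100000 nM.
Compound 2, `COc1ccc(Nc2ccc3cc(NC(=O)c4ccc(OC)c(-c5cccc(OC)c5)c4)c(=O)oc3c2C)cc1`: in this assay compound 2 gives only a limit, > 100000 nM.

Among the compounds with values here, the one measured step, a step that the two limits leave unreadable from compound 1 to compound 2, is not readable, because both of its ends sit at the assay limit (the limit of > 100000 nM in this assay, at which 2 of the 2 values shown sit). Within the data shown here, compound 2 therefore stands at that limit and nowhere more precisely; no numbered value exists anywhere so far.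

Compound 3, `COc1cccc(-c2cc(C(=O)Nc3cc4ccc(Cc5ccccc5)c(C)c4oc3=O)ccc2OC)c1`, differs from compound 2 by benzyl in place of (4-methoxyphenyl)amino on an aromatic carbon. Among the measured compounds shown here, no measured step bears on this change: the only step recorded involves a different pair of groups at the same place and its size is hidden by the limits. Nothing in the data points toward a gain or a loss beyond the scatter in this assay, and a further limit is the most likely outcome.

Compound 3 is accordingly expected to give about 90000 nM in this assay, within a range from 20000 nM to 300000 nM. This corresponds to an expected step of an at least 1.1-fold lower number from compound 2 to compound 3 (0.04 log units; that floor lies within the scatter), read with the caution that both ends may again be limits.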

Compound 3, half-maximal inhibitory concentration: 4090 nM
Compound 3: middle estimate off by 22-fold (1.34 log units), on the high side, and the stated range ends above it.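

Within the data shown here, at the aromatic carbon ortho to a methyl group, the first numbered value comes with benzyl, so this place can carry a readable antiproliferative effect in this assay (benzyl in place of (4-methoxyphenyl)amino: an at least 24-fold lower number from compound 2 to compound 3 (1.38 log units; beyond the scatter); benzyl in place of 4-methoxyphenoxy: an at least 24-fold lower number from compound 1 to compound 3 (1.38 log units; beyond the scatter)). All three groups hold one six-membered aromatic ring of carbon only, so the presence of that ring does not separate compound 3 from compound 1 or compound 2; benzyl differs from both other groups in the atom joining that ring to the core and in having no methoxy group. Each step gives only a minimum and not a true size, because its starting end is a limit: the limit of > 100000 nM in this assay, at which 2 of the 3 values shown sit.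

Which of these two differences accounts for the drop in the number stays open: 4-methoxybenzyl would keep the carbon link along with the methoxy group, while phenoxy would keep the oxygen link without it. Also open, from the compounds shown here alone, is how far this place tolerates a longer chain such as 2-phenylethyl, or a saturated ring such as cyclohexylmethyl in place of the aromatic one.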